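Benzofuranyl hydrazone thiazoles: antiproliferative series, next member

The source may hold more compounds than are shown below. What is called first, only, known or untested is meant among the compounds shown, and "the series" means these compounds.

Compounds measured so far in a functional assay on HepG2 cells (Homo sapiens) for antiproliferative activity; a lower number here means a stronger inhibitor, a higher number a weaker inhibitor:

- compound 1 `C/C(=N\Nc1nc(-c2ccc(Br)cc2)cs1)c1cc2ccccc2o1`: 27700 nM
- compound 2 `C/C(=N\Nc1nc(-c2ccccc2)cs1)c1cc2ccccc2o1`: 10300 nM
- compound 3 `CCOC(=O)Cc1csc(N/N=C(\C)c2cc3ccccc3o2)n1`: 7740 nM

Compound 3 stands at the lowest number of the three, with compound 2 nearest to it and compound 1 furthest away. The steps that lead to it are a 3.6-fold lower number from compound 1 to compound 3 (0.55 log units; beyond the scatter) and a 1.3-fold lower number from compound 2 to compound 3 (0.12 log units; within the scatter); the step of a 2.7-fold lower number from compound 1 to compound 2 (0.43 log units; beyond the scatter) separates the two aryl-bearing compounds from each other.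

Compound 4 `C/C(=N\Nc1nc(-c2cc3ccccc3o2)cs1)c1cc2ccccc2o1` is the next member. It differs from compound 3 in one place: 1-benzofuran-2-yl in place of (ethoxycarbonyl)methyl on an aromatic carbon. The group that enters is a second benzofuranyl, the same unit that already sits on the hydrazone carbon of the shared core.

For the measured compounds named here, the steps that bear on this change are those in which the group on that ring carbon was exchanged. Going from an aryl group to the (ethoxycarbonyl)methyl group gave a modest drop with compound 1 and no change beyond the scatter with compound 2. Returning to an aromatic group is therefore expected to give either no change beyond the scatter or a modest rise in number, with a bicyclic aromatic group weighted somewhat toward the direction that compound 1 showed. For compound 4 the expected step is a 1.7-fold higher number from compound 3 to compound 4 (0.23 log units; within the scatter). Compound 4 is estimated at 13000 nM, within a range from 4000 nM to 45000 nM in this assay.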

Compound 4, half-maximal inhibitory concentration: 21300 nM
Estimate against measurement, compound 4: 1.6-fold (0.21 log units) below; measured number inside the range.
By their numbers in this assay, from the lowest: compounds 3 and 2 (each within the scatter of the next); then compounds 4 and 1 (each within the scatter of the next).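

Working notes: in this assay, 1-benzofuran-2-yl on this aromatic carbon, next to the ring nitrogen, gives a 2.8-fold higher number from compound 3 to compound 4 (0.44 log units; beyond the scatter), so here an aromatic group and the (ethoxycarbonyl)methyl group lie beyond the scatter of each other, which the phenyl of compound 2 did not show against compound 3. The aromatic groups at this position also differ among themselves: the exchange of phenyl gives a 2.1-fold higher number from compound 2 to compound 4 (0.32 log units; beyond the scatter), while the exchange of 4-bromophenyl gives a 1.3-fold lower number from compound 1 to compound 4 (0.11 log units; within the scatter), which is within the scatter, so compound 4 and compound 1 form one level and compound 2 and compound 3 another, and an aromatic group alone does not decide the level. Nothing in hand explains why the numbers fall this way.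

Open, on these data alone, is how a carboxylic acid in place of the ethyl ester, or a longer chain ending in an amine, would stand on this ring carbon against compound 3. Also open, as far as these compounds go, is whether a single furan-2-yl ring here would fall with compound 2 or with compound 4, which would separate the fused benzene ring from the furan ring in this step.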